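A few compounds are considered here, and "the series" means these few. Any claim that something is new, unique, unknown or untested is made for them only; others in the source may bear on it.

Measured compounds:
- compound 1, `COc1ccc(C(OCc2ccccc2)c2cccc3ccccc23)c(OC)c1OC`: 14100 nM
- compound 2, `COc1ccc(C(c2ccc(OCCO)cc2)c2cccc3ccccc23)c(OC)c1OC`: > 20000 nM

Among the measured compounds shown here, compound 1 is the only compound of this pair with a true number in a functional assay on MCF7 cells (Homo sapiens) for inhibition, read by sulforhodamine B assay, with a stated time of 48 h; on this read-out higher numbers stand for weaker inhibition and lower numbers for stronger inhibition; in this assay compound 1 gives 14100 nM. Compound 2 gives only a limit of the assay in this assay, > 20000 nM, which is the limit of > 20000 nM in this assay, at which 1 of the 2 values shown sits. For the measured compounds named here, the single measured step, an at least 1.4-fold higher number from compound 1 to compound 2 (0.15 log units; that floor lies within the scatter), swaps the whole benzyloxy group for a different side group, so it says little about changes made within the benzyloxy group itself.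

Compound 3, `COc1cc(COC(c2ccc(OC)c(OC)c2OC)c2cccc3ccccc23)cc(OC)c1`, keeps the benzyloxy group of compound 1 and alters it only by 3,5-dimethoxyphenyl in place of phenyl on a saturated chain carbon bound to an oxygen on a saturated carbon. Going by the values given here, no measured step touches this part of the molecule, so there is no direct guide for the size or direction of the change. Adding two methoxy groups to the benzyl ring is a modest alteration, and with no evidence pointing either way the expectation is a step of about none beyond the scatter, a 1.0-fold lower number from compound 1 to compound 3 (0.00 log units; within the scatter). Compound 3 is therefore estimated at 14000 nM, with a range from 5000 nM to 40000 nM in this assay.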

Compound 3, half-maximal inhibitory concentration: > 20000 nM
Compound 3: only a limit was reported; the forecaster's own chance of this, stated with the estimate: 30%; middle value at least 1.4-fold (0.15 log units) away from the limit.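

Among the compounds shown here, compound 3 is the first compound here to change the benzyl group of compound 1 while leaving the shared core untouched, and in this assay compound 3 gives only a limit of the assay, > 20000 nM. Read as a step, the swap of benzyl for 3,5-dimethoxybenzyl is an at least 1.4-fold higher number from compound 1 to compound 3 (0.15 log units; that floor lies within the scatter), so adding the two methoxy groups gives no sign of stronger inhibition, while the true size of the change stays unknown. Like compound 2, compound 3 gives no true number, so two quite different changes to compound 1 both end at the same edge of what the assay can read: the limit of > 20000 nM in this assay, at which 2 of the 3 values shown sit.

Still open, from the compounds shown here alone, is whether a smaller change to the benzyl ring, such as a single methoxy group, a fluorine or a hydroxyl, would read differently from the plain benzyl of compound 1, at 14100 nM. Also open, going by these compounds, is whether an amine or a carboxylic acid on a longer chain at this place would give a true number in this assay, and whether that number would be lower.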